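The source may hold more compounds than are shown below. What is called first, only, known or untested is meant among the compounds shown, and "the series" means these compounds.

In a functional assay on DU-145 cells (Homo sapiens) for antiproliferative activity, read by MTT assay, with a stated time of 48 h (a higher number here means a weaker inhibitor, a lower number a stronger inhibitor), compound 1 (`C/C(=C\CC/C(C)=C/CC[C@@H]1[C@@]2(C)CCC(=O)C(C)(C)[C@H]2CC[C@@]1(C)O)CC/C=C(\C)C(=O)OCc1cn(-c2ccccc2C)nn1`) gives > 150000 nM, which is a limit of the assay. Compound 3 (`C/C(=C\CC/C(C)=C/CC[C@@H]1[C@@]2(C)CCC(=O)C(C)(C)[C@H]2CC[C@@]1(C)O)CC/C=C(\C)C(=O)OCc1cn(-c2cccc(F)c2)nn1`) gives > 150000 nM, also only a limit. That places it at the limit of > 150000 nM in this assay, at which 2 of the 3 values shown sit. Compound 2 (`C/C(=C\CC/C(C)=C/CC[C@@H]1[C@@]2(C)CCC(=O)C(C)(C)[C@H]2CC[C@@]1(C)O)CC/C=C(\C)C(=O)OCc1cn(-c2cccc(Cl)c2)nn1`) gives a number, 103000 nM. Compound 4 (`C/C(=C\CC/C(C)=C/CC[C@@H]1[C@@]2(C)CCC(=O)C(C)(C)[C@H]2CC[C@@]1(C)O)CC/C=C(\C)C(=O)OCc1cn(-c2ccccc2Cl)nn1`) carries 2-chlorophenyl in place of 3-fluorophenyl on an aromatic nitrogen. Going by the values given here, two measured steps bear on this change: an at least 1.4-fold higher number from compound 2 to compound 3 (0.16 log units; that floor lies within the scatter), for fluoro in place of chloro, and an at least 1.4-fold lower number from compound 1 to compound 2 (0.16 log units; that floor lies within the scatter), for 3-chlorophenyl in place of 2-methylphenyl. Neither gives a size beyond the scatter, so the expected result is no clear step, and a further limit is quite possible. The estimated change is an at least 1.1-fold lower number from compound 3 to compound 4 (0.06 log units; that floor lies within the scatter). For compound 4 the estimated value is 130000 nM, with an expected range from 70000 nM to 220000 nM.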

Compound 4, half-maximal inhibitory concentration: > 150000 nM
Compound 4 gave a limit, no number; the forecaster's own chance of this, stated with the estimate: 55%; middle value at least 1.1-fold (0.06 log units) away from the limit.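

With 2-chlorophenyl in place of 3-chlorophenyl, the result in this assay is an at least 1.4-fold higher number from compound 2 to compound 4 (0.16 log units; that floor lies within the scatter), so the chloro group on this ring does not lift the series to a number wherever it sits; the floor of this step is no clear separation. The steps from compound 1 and compound 3 to compound 4 join two limits and cannot be read. Compound 2 remains the only compound with a number, and the others share one limit: the limit of > 150000 nM in this assay, at which 3 of the 4 values shown sit.

The compounds shown leave open whether an amine or a carboxylic acid on this phenyl ring would give a number in this assay. They also leave open how far compound 1, compound 3 and compound 4 truly differ.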